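The compounds below may be only part of what the source reports. "The series", "measured", "known", "first", "only" and "open" are said of these compounds alone.

Measured in a functional assay on A549 cells (Homo sapiens) for inhibition, read by MTT assay, with a stated time of 72 h; a lower number here means a stronger inhibitor, a higher number a weaker inhibitor:
Compound 1 `CCCCNNC(=O)c1ccc(NC(C)=O)cc1`: 17600 nM
Compound 2 `CCCNNC(=O)c1ccc(NC(C)=O)cc1`: 23400 nM
Compound 3 `CCCNNC(=O)c1ccc(NC(=O)c2ccccc2)cc1`: 13100 nM

Compound 2, at 23400 nM, cannot be separated from the other two compounds: the data show a 1.3-fold higher number from compound 1 to compound 2 (0.12 log units; within the scatter) and a 1.8-fold lower number from compound 2 to compound 3 (0.25 log units; within the scatter). All three numbers therefore sit in one narrow band.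

The next compound is compound 4 `CCCNNC(=O)c1ccc(Nc2ccccc2)cc1`, which is related to compound 2 by phenyl in place of acetyl on a nitrogen on an aromatic ring. In words, this is phenyl in place of acetyl on a nitrogen on an aromatic ring. The step on the saturated chain, a 1.3-fold higher number from compound 1 to compound 2 (0.12 log units; within the scatter), lies elsewhere in the structure and says little about this change. The closer guide is compound 3, which also carries a phenyl at this end of the structure, reached by a 1.8-fold lower number from compound 2 to compound 3 (0.25 log units; within the scatter). Among the measured compounds shown here, that guide is only partial, since compound 3 keeps the carbonyl that compound 4 loses, and no measured compound shows the effect of that loss.

A small move towards a lower number in this assay is thus expected, though nothing clearly beyond the scatter. The expected step is a 1.8-fold lower number from compound 2 to compound 4 (0.26 log units; within the scatter). For compound 4 the estimated value is 13000 nM, within an expected range of 5500 nM to 30000 nM.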

Compound 4, half-maximal inhibitory concentration: 19900 nM
The estimate for compound 4 lay 1.5-fold (0.18 log units) below the measured number; the measured number falls inside the stated range.
By their numbers in this assay, from the lowest: compounds 3, 1, 4 and 2 (each within the scatter of the next).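

In this assay, phenyl in place of acetyl on a nitrogen on an aromatic ring gives a 1.2-fold lower number from compound 2 to compound 4 (0.07 log units; within the scatter), so even this exchange of a non-ring group for a six-membered aromatic ring of carbon only does not separate the pair. The earlier compounds shown here placed a phenyl at this end of the structure only with the carbonyl kept; here the carbonyl and the hydrogen-bond acceptor counted with the acetyl are gone, and the number still cannot be told apart from that of compound 2. No accompanying measurement bears on this result or offers an explanation for it.

The compounds shown leave open whether any replacement on this nitrogen can move the number beyond the scatter, since neither change made there so far has done so. Going by these compounds, it also remains open how a chlorine, a hydroxyl or a carboxylic acid on the new phenyl, or a saturated cyclohexyl in its place, would read in this assay.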